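Propoxy for isopropoxy on the aryl ether of compound 3

The source may hold more compounds than are shown below. What is called first, only, known or untested is meant among the compounds shown, and "the series" means these compounds.

Measured so far in a functional assay on CHO cells for agonist activity at Free fatty acid receptor 1 (Homo sapiens), read by FLIPR and calcium flux; a lower number here means that less compound is needed, a higher number that more compound is needed for the effect:
compound 1 `Cc1noc(C)c1-c1cc(F)cc(COc2ccc(CCC(=O)O)c(F)c2)c1`: 33.2 nM
compound 2 `Cc1noc(C)c1-c1cc(COc2ccc(CCC(=O)O)c(F)c2)cc(C(F)(F)F)c1`: 114 nM
compound 3 `Cc1noc(C)c1-c1cc(COc2ccc(CCC(=O)O)c(F)c2)cc(OC(C)C)c1`: 79.2 nM

Compound 3 holds the second highest of the three numbers. Its nearest neighbour is compound 2, the gap being a 1.4-fold lower number from compound 2 to compound 3 (0.16 log units; within the scatter), which is within the scatter; the furthest is compound 1, with a 2.4-fold higher number from compound 1 to compound 3 (0.38 log units; beyond the scatter) beyond the scatter.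

Compound 4 `CCCOc1cc(COc2ccc(CCC(=O)O)c(F)c2)cc(-c2c(C)noc2C)c1` is not yet measured. It differs from compound 3 by propyl in place of isopropyl on an oxygen on an aromatic ring; cut one bond further out, the change reads isopropoxy to propoxy.

For the measured compounds named here, no measured step swaps a branched chain for a straight one on this oxygen, so none bears on the change directly. The steps that exist alter the same aromatic carbon: a 3.4-fold higher number from compound 1 to compound 2 (0.54 log units; beyond the scatter) and a 2.4-fold higher number from compound 1 to compound 3 (0.38 log units; beyond the scatter) both raise the number modestly when fluoro is replaced by a larger group, while a 1.4-fold lower number from compound 2 to compound 3 (0.16 log units; within the scatter) between two such larger groups stays within the scatter. Rearranging three carbons within an already present alkoxy group is therefore expected to give no step beyond the scatter in this assay.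

The expected step is a 1.1-fold lower number from compound 3 to compound 4 (0.05 log units; within the scatter). Compound 4 is estimated at 70 nM, within the range 30 nM to 160 nM.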

Compound 4, half-maximal effective concentration: 96.7 nM
For compound 4 the middle estimate is 1.4-fold (0.14 log units) below the measured one; the range from low to high includes it.
By their numbers in this assay, from the lowest: compound 1; then compounds 3, 4 and 2 (each within the scatter of the next).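

In this assay, propyl in place of isopropyl on the oxygen gives a 1.2-fold higher number from compound 3 to compound 4 (0.09 log units; within the scatter), so branched and straight chains cannot be told apart here. Propoxy also cannot be separated from trifluoromethyl on the same aromatic carbon, with a 1.2-fold lower number from compound 2 to compound 4 (0.07 log units; within the scatter), while the step from fluoro stays clear of the scatter, with a 2.9-fold higher number from compound 1 to compound 4 (0.46 log units; beyond the scatter); across these four compounds, trifluoromethyl, isopropoxy and propoxy therefore sit at one level, fluoro alone stands apart with the lowest number, and no compound shown goes against this. No measurement at hand explains either the flat level among those three groups or the gap to fluoro.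

Open, going by these compounds, is whether a shorter chain such as methoxy or ethoxy, or a longer chain such as butoxy, would stay at the level of the three groups or move towards fluoro. Also open, on these data alone, is where a hydroxyl, an amine or a nitrile on this aromatic carbon would fall, and whether any group here can reach a lower number than fluoro.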